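This account rests on a few compounds, and the source may have more. Where it says the series, first, only, none or still open, it means among the compounds named here.

Compound 1 `COC(=O)c1sc2cc(-c3ccsc3)cnc2c1N` carries a thiophen-3-yl group on the shared core, and in a functional assay on MCF7 cells (Homo sapiens) for inhibition, read by sulforhodamine B assay, with a stated time of 48 h (on this read-out higher numbers stand for weaker inhibition of growth and lower numbers for stronger inhibition of growth), compound 1 gives 12700 nM. Compound 2 `COC(=O)c1sc2cc(-c3ccc(F)nc3)cnc2c1N` replaces that group with a 6-fluoropyridin-3-yl group, but in this assay compound 2 gives "not determined" (no result reported), so no single number describes where compound 2 stands.

Compound 3 `COC(=O)c1sc2cc(-c3cccc(N)c3)cnc2c1N` has not yet been measured. Its structure differs from compound 2 in one place: 3-aminophenyl in place of 6-fluoropyridin-3-yl on an aromatic carbon, so 3-aminophenyl stands in place of 6-fluoropyridin-3-yl on an aromatic carbon. Within the data shown here, no step between two measured compounds is available to anchor this change, and compound 2 itself has no number, so the only measured reference is compound 1. Against that background the change from compound 2 to compound 3 is expected to move the readout toward stronger inhibition, by a modest amount that may not exceed the scatter. In this assay compound 3 is therefore estimated at 6000 nM, with a range from 1500 nM to 25000 nM.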

Compound 3, concentration for 50% growth inhibition: > 150000 nM
Compound 3 gave a limit, no number (the forecaster's own chance of this, stated with the estimate: 20%); middle value at least 25-fold (1.39 log units) away from the limit.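

With a measured partner for compound 1 now available, this position on an aromatic carbon of the shared core proves sensitive to the group it carries: replacing thiophen-3-yl with 3-aminophenyl gives an at least 11-fold higher number from compound 1 to compound 3 (1.07 log units; beyond the scatter) in this assay, which on this read-out means weaker inhibition of growth. Among these compounds, the earlier compounds could not show this, as they offered only one number and no comparison at this position. The result for compound 3 is a limit of the assay and not a number, so the step gives only a lower bound on the size of the change: the limit of > 150000 nM in this assay, at which 1 of the 3 values shown sits.

Compound 2 has no number, so no step involving the 6-fluoropyridin-3-yl group can be read, and the compounds shown leave open how that group compares with either thiophen-3-yl or 3-aminophenyl. They also leave open whether the change follows the amine or the six-membered carbon ring itself, a question that a plain phenyl group or a 3-hydroxyphenyl group at this position would help to separate.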